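This account rests on a few compounds, and the source may have more. Where it says the series, first, only, none or still open, it means among the compounds named here.

Measured in a functional assay on HEK293 cells for agonist activity at probable G-protein coupled receptor 27 (Homo sapiens), read by a luciferase reporter and beta-arrestin recruitment, with a stated time of 10 min; on this read-out higher numbers stand for an effect only at larger amounts of compound and lower numbers for an effect already at smaller amounts:
- compound 1 `Cc1cc(Br)ccc1C(=O)Nc1ccc(S(=O)(=O)Nc2ccccc2)cc1` gives 851 nM
- compound 2 `O=C(Nc1ccc(S(=O)(=O)Nc2ccccc2)cc1)c1ccc(Cl)nc1F` gives 2290 nM
- compound 3 `O=C(Nc1ccc(S(=O)(=O)Nc2ccccc2)cc1)c1cc(F)c(Cl)cc1F` gives 141 nM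

Compound 3 stands lowest of the three, with a 6.0-fold lower number from compound 1 to compound 3 (0.78 log units; beyond the scatter) and a 16-fold lower number from compound 2 to compound 3 (1.21 log units; beyond the scatter) both beyond the scatter. Compound 4 `COc1cc(Br)ccc1C(=O)Nc1ccc(S(=O)(=O)Nc2ccccc2)cc1` is not yet measured; it differs from compound 3 by 4-bromo-2-methoxyphenyl in place of 4-chloro-2,5-difluorophenyl on a carbonyl carbon. Going by the values given here, the one measured step bearing on this is a 6.0-fold lower number from compound 1 to compound 3 (0.78 log units; beyond the scatter), and compound 4 carries 4-bromo-2-methoxyphenyl, close to the 4-bromo-2-methylphenyl of compound 1. The reverse of that step is therefore expected, a modest move to a higher number in this assay, about a 5.0-fold higher number from compound 3 to compound 4 (0.70 log units; beyond the scatter). Compound 4 is thus estimated at 700 nM, within 250 nM to 2500 nM.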

Compound 4, half-maximal effective concentration: 1020 nM
Beside the measured number, compound 4's estimate is 1.5-fold (0.16 log units) below it, within the range that was stated.
By their numbers in this assay, from the lowest: compound 3; then compounds 1 and 4 (each within the scatter of the next); then compound 2.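

In this assay methoxy in place of methyl on an aromatic carbon gives a 1.2-fold higher number from compound 1 to compound 4 (0.08 log units; within the scatter) and so leaves no readable difference at this place. The 4-bromo-2-methoxyphenyl group still gives a 7.2-fold higher number from compound 3 to compound 4 (0.86 log units; beyond the scatter) against 4-chloro-2,5-difluorophenyl and a 2.2-fold lower number from compound 2 to compound 4 (0.35 log units; beyond the scatter) against 6-chloro-2-fluoropyridin-3-yl. No measurement at hand accounts for these steps.

Open, as far as these compounds go, is whether a hydroxyl or an amine in place of methoxy on an aromatic carbon would also stay within the scatter of compound 1. Also open, from the compounds shown here alone, is whether either fluorine of compound 3 can be replaced by hydrogen without a move in the number.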